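Moving the chlorine on the urea aryl of compound 2

This account rests on a few compounds, and the source may have more. Where it says the series, first, only, none or still open, it means among the compounds named here.

Within the data shown here, in a functional assay on thoracic aorta (Rattus norvegicus) for inhibition (on this read-out higher numbers stand for an effect only at larger amounts of compound and lower numbers for an effect already at smaller amounts), compound 2 `CCS(=O)(=O)Nc1ccc2c(c1)C(NC(=O)Nc1cccc(Cl)c1)CC(C)(C)O2` gives 17200 nM, the only number among the values shown. Compound 1 `CC1(C)CC(NC(=O)Nc2ccc(Cl)cc2)c2cc(NS(C)(=O)=O)ccc2O1` gives > 30000 nM in this assay, which is a limit of the assay rather than a number. Compound 3 `CCS(=O)(=O)Nc1ccc2c(c1)C(NC(=O)Nc1ccc(Cl)cc1)CC(C)(C)O2` differs from compound 2 by 4-chlorophenyl in place of 3-chlorophenyl on an amide-type nitrogen. Compound 1, which also carries 4-chlorophenyl, sits at the limit of > 30000 nM in this assay, at which 1 of the 2 values shown sits, so a step towards weaker inhibition, possibly beyond the scatter, is expected from compound 2 to compound 3 in this assay, a 1.6-fold higher number from compound 2 to compound 3 (0.21 log units; within the scatter). Compound 3 is therefore estimated at 28000 nM in this assay, within 12000 nM to 60000 nM.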

Compound 3, half-maximal effective concentration: > 10000 nM
Compound 3 was reported as a limit (the forecaster's own chance of this, stated with the estimate: 45%); the middle value is on the limit's open side.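

In this assay, among these compounds, compound 3 gives > 10000 nM, a limit of the assay and not a number, so no step from compound 2 or compound 1 to compound 3 can be read. The compounds shown leave open how much 4-chlorophenyl in place of 3-chlorophenyl changes the read-out.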